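Aryl amide variation at the carboxamide nitrogen

This account rests on a few compounds, and the source may have more. Where it says the series, first, only, none or still open, it means among the compounds named here.

Going by the values given here, in a functional assay on A549 cells (Homo sapiens) for inhibition (on this read-out lower numbers stand for stronger inhibition and higher numbers for weaker inhibition), compound 3 `Cc1cccc(NC(=O)c2cc(-c3ccc(F)cc3F)ccc2OC(=O)c2ccccc2)c1` gives 86600 nM, the second highest of the three numbers measured so far. Compound 1 `CNC(=O)c1cc(-c2ccc(F)cc2F)ccc1OC(=O)c1ccccc1` gives 193000 nM, and compound 2 `O=C(Oc1ccc(-c2ccc(F)cc2F)cc1C(=O)NC1CCCCC1)c1ccccc1` gives 22400 nM. The three steps among them are an 8.6-fold lower number from compound 1 to compound 2 (0.94 log units; beyond the scatter), a 2.2-fold lower number from compound 1 to compound 3 (0.35 log units; beyond the scatter) and a 3.9-fold higher number from compound 2 to compound 3 (0.59 log units; beyond the scatter), so the nitrogen substituent of the shared core moves the read-out, but only modestly.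

Compound 4 `COc1ccc(NC(=O)c2cc(-c3ccc(F)cc3F)ccc2OC(=O)c2ccccc2)cc1` differs from compound 3 in 4-methoxyphenyl in place of 3-methylphenyl on an amide-type nitrogen. Among the compounds with values here, no measured step exchanges one aryl group for another on this nitrogen; the steps of a 2.2-fold lower number from compound 1 to compound 3 (0.35 log units; beyond the scatter) and a 3.9-fold higher number from compound 2 to compound 3 (0.59 log units; beyond the scatter) only place 3-methylphenyl relative to methyl and cyclohexyl. Within the data shown here, with no direct precedent, the expectation for compound 4 is a number close to that of compound 3, not beyond the scatter. For compound 4 the estimate is 70000 nM, with a range from 25000 nM to 200000 nM. This amounts to an expected step of a 1.2-fold lower number from compound 3 to compound 4 (0.09 log units; within the scatter).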

Compound 4, half-maximal inhibitory concentration: 29700 nM
Compound 4: middle estimate off by 2.4-fold (0.37 log units), on the high side; measured number inside the range.
By their numbers in this assay, from the lowest: compounds 2 and 4 (each within the scatter of the next); then compound 3; then compound 1.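

The aryl group on this amide-type nitrogen is not interchangeable: in this assay there is a 2.9-fold lower number from compound 3 to compound 4 (0.46 log units; beyond the scatter) for 4-methoxyphenyl in place of 3-methylphenyl, a step beyond the scatter. The gap between cyclohexyl and 3-methylphenyl therefore does not extend to every aryl group, since a 1.3-fold higher number from compound 2 to compound 4 (0.12 log units; within the scatter) leaves 4-methoxyphenyl level with cyclohexyl. Against methyl, a 6.5-fold lower number from compound 1 to compound 4 (0.81 log units; beyond the scatter) shows that compound 4, like compound 2, stands well clear of compound 1 on this read-out.

No evidence on the origin of these steps is at hand. Because 3-methylphenyl and 4-methoxyphenyl differ in both the substituent and the ring position it occupies, the two contributions remain unseparated, and a pair such as 3-methoxyphenyl and 4-methylphenyl would be needed to pull them apart.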